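Vanilloid receptor antagonists: a thioether variant of the amide

The source may hold more compounds than are shown below. What is called first, only, known or untested is meant among the compounds shown, and "the series" means these compounds.

Measured so far:
compound 1, `CC(C)(C)c1ccc(NC(=O)c2ccc(OC(F)(F)C(F)F)cc2)cc1` — 70 nM
compound 2, `O=C(Nc1ccc2c(c1)CCC2)c1ccc(OC(F)(F)F)cc1` — 210 nM
compound 3, `O=C(Nc1ccc(C2CCCCC2)cc1)c1ccc(OC(F)(F)F)cc1` — the assay reports a limit, > 10000 nM

In a functional assay on HEK293 cells for antagonist activity at transient receptor potential cation channel subfamily V member 1 (Homo sapiens), read by calcium flux (a lower number here means a stronger inhibitor, a higher number a weaker inhibitor), compound 1 holds the lowest of the two numbers shown. Compound 2, which differs from it on both sides of the amide, sits at a higher number, and the gap between the two lies beyond the usual scatter. For compound 3 the assay reports only a limit, (the limit of > 10000 nM in this assay, at which 1 of the 3 values shown sits); it is a limit of the assay and not a number, and no more is said of it here.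

Compound 4, `CC(C)(C)c1ccc(NC(=O)c2ccc(SC(F)(F)F)cc2)cc1`, is the next compound to be measured. It differs from compound 1 in one place: (trifluoromethyl)sulfanyl in place of 1,1,2,2-tetrafluoroethoxy on an aromatic carbon. Going by the values given here, no measured pair shows this change, so its size cannot be read from the data. The amide and the group at the other end of the core are unchanged, and the substituent that enters is again a small fluorinated group at the same place. The expectation is therefore a step that stays within the scatter, or a modest move in either direction, rather than a large one.

On that basis compound 4 is estimated at 80 nM, with a range from 25 nM to 300 nM. The expected step is a 1.1-fold higher number from compound 1 to compound 4 (0.06 log units; within the scatter).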

Compound 4, half-maximal inhibitory concentration: 253 nM
Beside the measured number, compound 4's estimate is 3.2-fold (0.50 log units) below it, within the range that was stated.
By their numbers in this assay, from the lowest: compound 1; then compounds 2 and 4 (each within the scatter of the next). At a limit, above all of these: compound 3.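

In this assay, the step is a 3.6-fold higher number from compound 1 to compound 4 (0.56 log units; beyond the scatter) on replacing 1,1,2,2-tetrafluoroethoxy with (trifluoromethyl)sulfanyl on an aromatic carbon para to a large group. Going by these compounds alone, this is the first change confined to one place, and it shows that the read-out responds to the choice of group at this position, even with the amide and the other end of the core unchanged. The two small fluorinated groups are therefore not interchangeable here, although the step is modest, and the information available offers no explanation for it.

The change alters both the atom joined to the ring and the fluorinated chain, so this single step cannot assign the difference to either one. On these data alone, it also remains open how the core of compound 1 would respond to a (1,1,2,2-tetrafluoroethyl)sulfanyl group, which would separate those two parts of the change, or to a group of another kind at this place, such as a nitrile or a methoxy group.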